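Swapping a Benzyl Amine for a Piperidine Ring

A few compounds are considered here, and "the series" means these few. Any claim that something is new, unique, unknown or untested is made for them only; others in the source may bear on it.

Of the compounds shown here, three built on one shared core have been measured in an assay on CHO cells for inhibition of sodium channel protein type 2 subunit alpha (Rattus norvegicus); a lower number here means a stronger inhibitor, a higher number a weaker inhibitor. Compound 1 `CN(CCCNC(=O)C(c1ccccc1)c1ccccc1)Cc1ccccc1` gives 1200 nM. Compound 2 `CC(CNC(=O)C(c1ccccc1)c1ccccc1)CN1CCC(c2ccccc2)CC1` gives 1500 nM, and compound 3 `O=C(NCCCN1CCC(n2c(O)nc3ccccc32)CC1)C(c1ccccc1)c1ccccc1` gives 720 nM. Compound 1 holds the second highest of the three numbers, yet its gap to compound 2 and its gap to compound 3 both lie within the usual scatter of repeated measurements, so none of the three can be ranked against the others.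

Compound 4 `O=C(NCCCCN1CCCCC1)C(c1ccccc1)c1ccccc1` has not yet been measured. It differs from compound 1 in one place: (piperidin-1-yl)methyl in place of benzyl(methyl)amino on a saturated chain carbon, three bonds along the chain from an amide-type nitrogen. The amine nitrogen keeps a similar distance from the amide, but the aromatic ring hanging from it gives way to a non-aromatic ring that contains the nitrogen. Compound 2 and compound 3 also carry their amine nitrogen inside a six-membered non-aromatic ring, and their numbers lie close to that of compound 1. Among the compounds with values here, no step between measured compounds exists for this exact change, so the expectation rests on that comparison alone.

Compound 4 is expected to give about 1500 nM, with a plausible range from 600 nM to 3500 nM. The step from compound 1 to compound 4 is therefore expected to be a 1.3-fold higher number from compound 1 to compound 4 (0.10 log units; within the scatter), not beyond the scatter.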

Compound 4, half-maximal inhibitory concentration: 10000 nM
The estimate for compound 4 lay 6.7-fold (0.82 log units) below the measured number; measured number above the stated range.
By their numbers in this assay, from the lowest: compounds 3, 1 and 2 (each within the scatter of the next, the first and the last beyond it); then compound 4.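

In this assay, replacing benzyl(methyl)amino with (piperidin-1-yl)methyl on a saturated chain carbon, three bonds along the chain from an amide-type nitrogen, gives an 8.3-fold higher number from compound 1 to compound 4 (0.92 log units; beyond the scatter). Within the data shown here, this is the first change in a single place that can be read in this set, and it shows that inhibition is sensitive to the group at this position, with the higher number marking a weaker inhibitor. The swap removes a six-membered aromatic ring of carbon only and brings in a six-membered non-aromatic ring with one hetero atom, but no measurement available here accounts for the difference in inhibition.

The compounds shown do not separate the loss of the aromatic ring from the placing of the amine nitrogen inside a ring, and compound 2 and compound 3 cannot settle this, as each differs from compound 4 in more than one place. A dimethylamino group at the same position, with no ring at all, or a morpholine ring in place of the piperidine, would be a direct way to probe which part of the swap matters.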